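A few compounds are considered here, and "the series" means these few. Any claim that something is new, unique, unknown or untested is made for them only; others in the source may bear on it.

Measured so far:
Compound 1 `C/C(=C\C(=O)Nc1ccccc1OCCCC(=O)O)c1ccc2c(ccn2C)c1` gives 780 nM in an assay on Prostate gland for inhibition of steroid 5-alpha-reductase (Rattus norvegicus); on this read-out higher numbers stand for weaker inhibition and lower numbers for stronger inhibition.
Compound 2 `CCCCCCCn1ccc2cc(/C(C)=C/C(=O)Nc3ccccc3OCCCC(=O)O)ccc21` gives 120 nM in this assay.

Among the measured compounds shown here, compound 2 has the lower of the two numbers; the only known step is a 6.5-fold lower number from compound 1 to compound 2 (0.81 log units; beyond the scatter), a chain added on the aromatic nitrogen of the shared core. Compound 3 `CCCC(CC)n1ccc2cc(/C(C)=C/C(=O)Nc3ccccc3OCCCC(=O)O)ccc21` keeps that chain but reshapes it: 1-ethylbutyl in place of heptyl on an aromatic nitrogen. For the measured compounds named here, no measured step shows what a shorter, branched chain does, so the bearing of the known step is indirect. The expectation for this assay is therefore a small step, if any, toward a higher number, a 1.7-fold higher number from compound 2 to compound 3 (0.22 log units; within the scatter), with compound 3 estimated at 200 nM (range 70 nM to 600 nM).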

Compound 3, half-maximal inhibitory concentration: 9.3 nM
For compound 3 the middle estimate is 22-fold (1.33 log units) above the measured one, outside the stated range (below it).
By their numbers in this assay, from the lowest: compound 3; then compound 2; then compound 1.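

On the aromatic nitrogen, the shape of the chain matters as well as its presence: in this assay, replacing heptyl with 1-ethylbutyl gives a 13-fold lower number from compound 2 to compound 3 (1.11 log units; beyond the scatter), although the new group has 6 heavy atoms against 7. Measured against methyl at the same place, 1-ethylbutyl gives an 84-fold lower number from compound 1 to compound 3 (1.92 log units; beyond the scatter). No measurement here explains why this branched chain gives the lowest number.

On these data alone, it remains open whether branching or chain length drives the step; an unbranched hexyl chain on this nitrogen would help separate the two. A cyclopentyl group would test whether a ring can serve there as well.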